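A few compounds are considered here, and "the series" means these few. Any claim that something is new, unique, unknown or untested is made for them only; others in the source may bear on it.

Compound 1 `Cc1ccc2ncc(S(=O)(=O)c3ccc(C)c(Cl)c3)c(N3CCC(C)CC3)c2c1`: 91% in an assay on isolated protein for displacement of a labelled ligand from metabotropic glutamate receptor 5 (Homo sapiens), with a stated time of 60 min, tested at 1 uM; a higher number here means more inhibition at the concentration tested (going by the name of the read-out), a lower number less inhibition
Compound 2 `Cc1ccc(S(=O)(=O)c2cnc3ccc(Cl)cc3c2N2CCC(C)CC2)cc1Cl`: 81%

Among the measured compounds shown here, compound 1 has the highest of the two numbers in this assay, and the only measured step, a number 10 percentage points lower from compound 1 to compound 2 (within the scatter), is within the scatter. Compound 3 `Cc1ccc2ncc(S(=O)(=O)c3cccc(C#N)c3)c(N3CCC(C)CC3)c2c1` differs from compound 1 by 3-cyanophenyl in place of 3-chloro-4-methylphenyl on a sulfonyl sulfur. For the measured compounds named here, no measured step touches the group on the sulfonyl sulfur; the one known step changes a different position and gives no guidance here, so no direction can be drawn from the data. A modest drop is estimated, a number 21 percentage points lower from compound 1 to compound 3 (beyond the scatter), with compound 3 expected to give 70% in this assay, within 40% to 95%.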

Compound 3, a percentage reported as inhibition, at one concentration (the size of the read-out at that concentration, not a potency): 52%
Compound 3: middle estimate off by 18 percentage points, on the high side; measured number inside the range.
By their numbers in this assay, from the lowest: compound 3; then compounds 2 and 1 (each within the scatter of the next).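

The group on the sulfonyl sulfur clearly matters: with the rest of the molecule unchanged, 3-cyanophenyl in place of 3-chloro-4-methylphenyl gives a number 39 percentage points lower from compound 1 to compound 3 (beyond the scatter) and so moves the number far more than the earlier chloro-for-methyl change on an aromatic carbon did. The two groups match in heavy-atom count and both carry one six-membered aromatic ring, so this change lies in the substituents on that ring, not in the ring itself. No measurement offered here accounts for the drop. Still open, from the compounds shown here alone, is which part of the swap carries the loss: the nitrile arriving, or the chloro or methyl leaving. How an amine or a carboxylic acid on this phenyl ring would fare is also unknown.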